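The source may hold more compounds than are shown below. What is called first, only, known or untested is meant among the compounds shown, and "the series" means these compounds.

In an ADME assay on EA.hy 926 cells (Homo sapiens) for inhibition, read by sulforhodamine B assay, with a stated time of 72 h (on this read-out higher numbers stand for weaker inhibition and lower numbers for stronger inhibition), compound 1 `CCC(C)NC(=C\C(=O)/C=C/c1ccc(O)c(OC)c1)/C=C/c1ccc(O)c(OC)c1` gives > 25000 nM as a limit and not a number. Compound 2 `C=CCNC(=C\C(=O)/C=C/c1ccc(O)c(OC)c1)/C=C/c1ccc(O)c(OC)c1` gives > 25000 nM as a limit too. Compound 3 `COc1cc(/C=C/C(=O)/C=C(/C=C/c2ccc(O)c(OC)c2)NC2CCCCC2)ccc1O` gives > 25000 nM as a limit as well. The three stand together as the limit of > 25000 nM in this assay, at which 3 of the 3 values shown sit, in this series. Compound 4 `COc1cc(/C=C/C(=O)/C=C(/C=C/c2ccc(O)c(OC)c2)NCC(C)C)ccc1O` changes one group of compound 3: isobutyl in place of cyclohexyl on an amine nitrogen. Three measured steps bear on it: a step that the two limits leave unreadable from compound 1 to compound 2 and a step that the two limits leave unreadable from compound 1 to compound 3 and a step that the two limits leave unreadable from compound 2 to compound 3 are all that is shown. Compound 3 offers no size to carry over in a step that the two limits leave unreadable from compound 2 to compound 3 and so no step beyond the scatter is expected. The estimated step is a step that the limit leaves unreadable from compound 3 to compound 4 on this reading. Compound 4 is expected at 30000 nM within an estimated range of 15000 nM to 60000 nM and most likely as a limit again.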

Compound 4, half-maximal inhibitory concentration: > 25000 nM
Compound 4: no number, only a limit (the forecaster's own chance of this, stated with the estimate: 85%); the middle value does not contradict the limit.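

No step can be read between compound 4 and compounds 1, 2 or 3, since each value is a limit and not a number: the limit of > 25000 nM in this assay, at which 4 of the 4 values shown sit. The compounds shown leave open how strongly any of the four inhibits, and whether the group on the amine nitrogen changes that.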